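The source may report more compounds than this note shows. Statements on the series, on what has been measured and on what is new or still open speak of the compounds shown alone.

Measured in a functional assay on MCF7 cells (Homo sapiens) for inhibition, read by sulforhodamine B assay; on this read-out higher numbers stand for weaker inhibition and lower numbers for stronger inhibition:
Compound 1 `O=C1C=C(Nc2ccccc2F)C(=O)c2c1nc1n2[C@H]2OC[C@@H](O)[C@H]2OC1`: 3640 nM
Compound 2 `CCOc1ccccc1NC1=CC(=O)c2nc3n(c2C1=O)[C@H]1OC[C@@H](O)[C@H]1OC3`: > 4000 nM

Compound 2 stands at > 4000 nM, which is a limit of the assay and not a number. That value is the limit of > 4000 nM in this assay, at which 1 of the 2 values shown sits.

Compound 3 `Cc1ccc(NC2=CC(=O)c3nc4n(c3C2=O)[C@H]2OC[C@@H](O)[C@H]2OC4)cc1` carries 4-methylphenyl in place of 2-ethoxyphenyl on an amine nitrogen. Among the measured compounds shown here, the one measured step, an at least 1.0-fold higher number from compound 1 to compound 2 (0.04 log units; that floor lies within the scatter), also alters the aromatic group on an amine nitrogen, and it lies within the scatter. For the measured compounds named here, it is the only guide available, and it concerns a different swap, so no step beyond the scatter is expected in this assay, in either direction. Compound 1, at 3640 nM, therefore sets the expected level. The estimated step is an at least 1.1-fold lower number from compound 2 to compound 3 (0.05 log units; that floor lies within the scatter). For compound 3 the expected value is 3500 nM, with an estimated range of 1400 nM to 8000 nM.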

Compound 3, half-maximal inhibitory concentration: 1660 nM
Compound 3: middle estimate off by 2.1-fold (0.32 log units), on the high side, within the range that was stated.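

In this assay, among the compounds shown here, changing the aromatic group on the amine nitrogen can move the number beyond the scatter, which the first pair of compounds did not show. Putting 4-methylphenyl in place of 2-fluorophenyl gives a 2.2-fold lower number from compound 1 to compound 3 (0.34 log units; beyond the scatter), and putting it in place of 2-ethoxyphenyl gives an at least 2.4-fold lower number from compound 2 to compound 3 (0.38 log units; beyond the scatter). Compound 2 has a limit of the assay and not a number, so the second step is only a floor: the limit of > 4000 nM in this assay, at which 1 of the 3 values shown sits.

On these data alone, whether the lower number goes with the methyl group itself or with where it sits on the aromatic ring stays open, since 2-fluorophenyl, 2-ethoxyphenyl and 4-methylphenyl differ in both. Also open, as far as these compounds go, is how this read-out would respond to an amine or a carboxylic acid on that ring, or to a longer chain in place of the aromatic group.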